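The source may report more compounds than this note shows. Statements on the series, on what has been measured and on what is new or still open speak of the compounds shown alone.

Measured in a functional assay on DU-145 cells (Homo sapiens) for antiproliferative activity, read by sulforhodamine B assay, with a stated time of 48 h; a lower number here means a stronger inhibitor of growth, a higher number a weaker inhibitor of growth:
- compound 1 `CCCNc1nc(Nc2ccc(OC)cc2)nc2ccccc12`: 4080 nM
- compound 2 `Nc1ccc(Nc2nc(NCCCO)c3ccccc3n2)cc1`: 20800 nM
- compound 3 `OCCCNc1nc(Nc2ccc(F)cc2)nc2ccccc12`: 20600 nM

Compound 3 at 20600 nM stands level with compound 2 within the scatter, and both lie higher than compound 1, a gap beyond the scatter.

The next compound is compound 4 `CCCNc1nc(Nc2ccc(F)cc2)nc2ccccc12`, which is reached from compound 3 by one change: hydrogen in place of hydroxy on a saturated chain carbon, three bonds along the chain from a nitrogen on an aromatic ring. In words, this is hydrogen in place of hydroxy on a saturated chain carbon, three bonds along the chain from a nitrogen on an aromatic ring, so 3-hydroxypropyl becomes propyl.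

For the measured compounds named here, no measured step changes this chain alone. Going by the values given here, the one measured step, a 1.0-fold lower number from compound 2 to compound 3 (0.00 log units; within the scatter), is fluoro in place of amino on an aromatic carbon, and it stays within the scatter, so that group made no visible difference in this pair. The nearest guide is compound 1 at 4080 nM, which carries the propyl chain of compound 4 but has a methoxy group where compound 4 has fluoro. Compound 4 is therefore expected to land nearer compound 1 than compound 3, though this rests on a single comparison in which two places differ.

The expected size and direction are given by the estimated 3.4-fold lower number from compound 3 to compound 4 (0.54 log units; beyond the scatter), a lower number beyond the scatter. In this assay compound 4 is estimated at 6000 nM with an expected range from 2500 nM to 15000 nM as its likely bounds.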

Compound 4, concentration for 50% growth inhibition: 4200 nM
For compound 4 the middle estimate is 1.4-fold (0.15 log units) above the measured one, within the range that was stated.
By their numbers in this assay, from the lowest: compounds 1 and 4 (each within the scatter of the next); then compounds 3 and 2 (each within the scatter of the next).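

In this assay, for the compounds shown here, the change of 3-hydroxypropyl to propyl gives a 4.9-fold lower number from compound 3 to compound 4 (0.69 log units; beyond the scatter) and is the first measured step at this place on the chain, with the fluoro group held the same. With the propyl chain in place, exchanging the methoxy group for a fluoro group gives a 1.0-fold higher number from compound 1 to compound 4 (0.01 log units; within the scatter) and so makes no visible difference in this pair, which matches a 1.0-fold lower number from compound 2 to compound 3 (0.00 log units; within the scatter) on the 3-hydroxypropyl chain, so among these four compounds only the chain step lies beyond the scatter. Nothing available here explains why removing the hydroxy shifts the number in this way.

As far as these compounds go, it remains open whether an amine or a carboxylic acid at the end of the chain would behave like the hydroxy or like the hydrogen, and how a longer chain such as butyl would compare with propyl. It is also open whether the step from 3-hydroxypropyl to propyl keeps its size when the aromatic carbon carries amino or methoxy instead of fluoro, since the only such step shown has fluoro there.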